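Imidazole in place of pyridine on the guanidine side chain

The source may hold more compounds than are shown below. What is called first, only, known or untested is meant among the compounds shown, and "the series" means these compounds.

Compound 1 `CC(CC(=O)/N=C(\N)NCCCc1cccnc1)c1ccccc1` and compound 2 `CC(CC(=O)/N=C(\N)NCCCc1ccncc1)c1ccccc1` share one core and differ only in the ring at the end of the three-carbon chain. In a functional assay on Sf9 cells for antagonist activity at histamine H2 receptor (Homo sapiens), with stated times of 2 min and 20 min (a higher number here means a more potent compound, by a factor of ten per unit of this negative logarithm, a lower number a less potent compound), compound 1 gives 5.27, and compound 2 gives 5.54. The one measured step, a number 0.27 log units higher from compound 1 to compound 2 (within the scatter), lies within the scatter, so the two compounds stand together on the numbers shown and neither can be set apart from the other.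

Compound 3 `CC(CC(=O)/N=C(\N)NCCCn1ccnc1)c1ccccc1` is not yet measured. It differs from compound 2 by 1H-imidazol-1-yl in place of pyridin-4-yl on a saturated chain carbon, three bonds along the chain from an amine nitrogen. Among the compounds with values here, no measured step involves this change: the only step on record exchanges one pyridinyl ring for another and therefore says nothing about a five-membered ring with two hetero atoms entering in its place. The data give no ground for a large step in either direction, and a modest shift with a wide margin is the most that can be expected.

For compound 3 in this assay the estimate is 5.4, between 4.8 and 6. This estimate means an expected step of a number 0.14 log units lower from compound 2 to compound 3 (within the scatter).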

Compound 3, negative logarithm of the antagonist equilibrium constant: < 5
Compound 3 ended at the assay's limit; the forecaster's own chance of this, stated with the estimate: 10%; middle value at least 0.40 log units away from the limit.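

The ring at the end of the three-carbon chain turns out not to be freely exchangeable, which the swap between the two pyridinyl rings could not show, since compound 1 and compound 2 stay within the scatter of each other. Within the data shown here, with 1H-imidazol-1-yl in place of pyridin-4-yl on that saturated chain carbon, this assay gives a number at least 0.54 log units lower from compound 2 to compound 3 (beyond the scatter), and this is the first step at this position to pass beyond the scatter. Against the other pyridinyl ring the same exchange gives only a number at least 0.27 log units lower from compound 1 to compound 3 (that floor lies within the scatter), so the result does not separate compound 3 from compound 1, and the value of compound 3 is a limit of the assay and not a number: the limit of < 5 in this assay, at which 1 of the 3 values shown sits.

As far as these compounds go, how far compound 3 really lies under that limit stays unknown, so the full size of both steps is open. The compounds shown also leave open whether the loss belongs to the five-membered ring as such or to its attachment through nitrogen, which a 1H-imidazol-4-yl group on the same chain, or the 1H-imidazol-1-yl group on a longer chain, would address.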